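The source may report more compounds than this note shows. Statements on the series, on what has been measured and on what is new or still open speak of the compounds shown alone.

Compound 1 `COc1cc2c(cc1OC)C(CC(N)=O)CC2` gives 31% in a functional assay on the whole organism (strain Wistar) for inhibition, with Rattus norvegicus as the target, read by paw edema, with stated times of 60 min and 2 h, at a dose of 100 mg/kg by the oral route; a lower number here means less inhibition, a higher number more inhibition at the dose given (going by the name of the read-out).
Compound 2 `COc1cc2c(cc1OC)C(CC(=O)NC1CCCC1)CC2` gives 52% in this assay.

Compound 2 holds the higher of the two numbers, standing above compound 1 by a number 21 percentage points higher from compound 1 to compound 2 (beyond the scatter). Compound 3 `COc1cc2c(cc1OC)C(CC(=O)N1CCNCC1)CC2` is not yet measured. It differs from compound 2 in one place: piperazin-1-yl in place of cyclopentylamino on a carbonyl carbon. Going by the values given here, the only measured step, a number 21 percentage points higher from compound 1 to compound 2 (beyond the scatter), came from cyclopentyl in place of hydrogen on an amide-type nitrogen and was modest. Among the compounds with values here, the change to compound 3 instead replaces one ring-bearing group with another on the carbonyl carbon, and no measured step compares two such groups, so the known step bears on it only indirectly. The step from compound 2 to compound 3 is therefore expected to be small, possibly within the scatter, in either direction. Compound 3 is estimated at 45%, with a range of 25% to 65%. That estimate amounts to an expected step of a number 7 percentage points lower from compound 2 to compound 3 (within the scatter).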

Compound 3, a percentage reported as inhibition, in the whole organism at one dose (the size of the read-out at that dose, not a potency): 44%
The estimate for compound 3 lay 1 percentage points above the measured number; the range from low to high includes it.
By their numbers in this assay, from the lowest: compound 1; then compounds 3 and 2 (each within the scatter of the next).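

At this carbonyl carbon, piperazin-1-yl in place of cyclopentylamino gives a number 8 percentage points lower from compound 2 to compound 3 (within the scatter) in this assay, so these two rings, which differ in size and in their ring atoms, cannot be told apart by this read-out. Going by these compounds alone, measured against the plain amide, piperazin-1-yl in place of amino gives a number 13 percentage points higher from compound 1 to compound 3 (beyond the scatter), which shows that cyclopentylamino is not the only group on this carbon to stand clearly above amino. Nothing available explains why either group gives these numbers.

Still open, as far as these compounds go, is whether a ring is needed at all, which an open-chain group such as diethylamino on the same carbonyl carbon could test. Morpholin-4-yl, with oxygen in place of the second ring nitrogen, could show whether that nitrogen matters.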